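This account rests on a few compounds, and the source may have more. Where it says the series, first, only, none or still open, it means among the compounds named here.

Compound 1 `C[C@H](c1ccccc1)N1C(=O)O[C@](Cc2ccccc2)(c2nc(-c3ccccc3)co2)C1=O` gives 73% in an ADME assay (liver) for metabolic stability, with Liver microsome (Homo sapiens) as the target, using microsomes, with a stated time of 0.5 h, tested at 1 uM; a higher number here means that more of the compound is left, a lower number that less of the compound is left. Compound 2 `C[C@H](c1ccccc1)N1C(=O)O[C@](Cc2ccccc2)(c2ncc(Cc3ccccc3)o2)C1=O` gives 0%. Compound 3 `C[C@H](c1ccccc1)N1C(=O)O[C@](Cc2ccccc2)(c2ncc(-c3ccccc3)[nH]2)C1=O` gives 62%.

Compound 3 stands second highest of the three numbers: the step of a number 11 percentage points lower from compound 1 to compound 3 (beyond the scatter) is beyond the scatter, while compound 2 lies far below it. Compound 4 `COc1cc(OC)cc(-c2cnc([C@@]3(Cc4ccccc4)OC(=O)N([C@H](C)c4ccccc4)C3=O)[nH]2)c1` differs from compound 3 by 3,5-dimethoxyphenyl in place of phenyl on an aromatic carbon. Among the measured compounds shown here, no measured step touches this ring of compound 3; the only step on record, a number 11 percentage points lower from compound 1 to compound 3 (beyond the scatter), concerns the five-membered ring and gives no guide to the new substituent. The expectation is therefore uncertain, with a wide range and a lean downward. Compound 4 is estimated at 40% (10% to 70%), a step of a number 22 percentage points lower from compound 3 to compound 4 (beyond the scatter) expected from compound 3.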

Compound 4, percent of the compound remaining: 43%
Beside the measured number, compound 4's estimate is 3 percentage points below it; measured number inside the range.
By their numbers in this assay, from the lowest: compound 2; then compound 4; then compound 3; then compound 1.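

Replacing phenyl with 3,5-dimethoxyphenyl on an aromatic carbon of the five-membered aromatic ring with 2 nitrogen gives a number 19 percentage points lower from compound 3 to compound 4 (beyond the scatter) in this assay. This is the only step shown at this position, and it shows that the aryl group here affects how much compound remains, although compound 4 is not fully lost. The data on hand offer no explanation for this step.

Going by these compounds, it remains open whether a single methoxy group would give a similar step. On these data alone, the effect of a carboxylic acid or an amine on this phenyl also remains unknown.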